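Three Bcl-2 inhibitors at the limit, a fourth untested

The source may hold more compounds than are shown below. What is called first, only, known or untested is meant among the compounds shown, and "the series" means these compounds.

Compound 1 `O=C(O)c1ccc(COc2ccc(/C=C3\SC(=S)N(c4ccc([N+](=O)[O-])cc4)C3=O)cc2)cc1`, compound 2 `O=C(COc1ccc(/C=C2\SC(=S)N(c3ccc([N+](=O)[O-])cc3)C2=O)cc1)Nc1ccc(C(=O)O)cc1` and compound 3 `Cc1cccc(N2C(=O)/C(=C/c3ccc(OCc4ccc(C(=O)O)cc4)cc3)SC2=S)c1` were tested in an assay on isolated protein for inhibition of Apoptosis regulator Bcl-2 (Homo sapiens), read by fluorescence polarization; on this read-out lower numbers stand for stronger inhibition and higher numbers for weaker inhibition. Compound 1 gives only a limit of the assay, > 10000 nM. Compound 2 likewise gives only a limit, > 10000 nM. Compound 3 also gives only a limit, > 10000 nM. The change from compound 1 to compound 2 is (4-carboxyphenyl)carbamoyl in place of 4-carboxyphenyl on a saturated chain carbon bound to an oxygen on an aromatic ring, and its step is a step that the two limits leave unreadable from compound 1 to compound 2. The change from compound 1 to compound 3 is 3-methylphenyl in place of 4-nitrophenyl on an amide-type nitrogen in a ring, with step that the two limits leave unreadable from compound 1 to compound 3. Compound 4 `Cc1cccc(N2C(=O)/C(=C/c3ccc(OCC(=O)Nc4ccc(C(=O)O)cc4)cc3)SC2=S)c1` is not yet measured; it differs from compound 2 by 3-methylphenyl in place of 4-nitrophenyl on an amide-type nitrogen in a ring, the same change as from compound 1 to compound 3. The step from compound 2 to compound 4 in this assay is expected to be a step that the limit leaves unreadable from compound 2 to compound 4 because all three measured values sit at the limit of > 10000 nM in this assay, at which 3 of the 3 values shown sit. Compound 4 is therefore expected to give 30000 nM, between 10000 nM and 200000 nM, most likely again only as a limit.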

Compound 4, inhibition constant: > 10000 nM
Compound 4 gave a limit, no number; the forecaster's own chance of this, stated with the estimate: 90%; the middle value is on the limit's open side.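

Going by these compounds alone, compound 2 and compound 4 both give only a limit of the assay, so no step between them can be read: the limit of > 10000 nM in this assay, at which 4 of the 4 values shown sit.

The compounds shown leave open whether 3-methylphenyl in place of 4-nitrophenyl changes inhibition of Bcl-2 at all.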